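A few compounds are considered here, and "the series" means these few. Any claim that something is new, unique, unknown or untested is made for them only; others in the source may bear on it.

Within the data shown here, compound 1, of structure `COc1cc(-c2cc(C(=O)O)c3ccccc3n2)ccc1OCC(=O)Nc1cccc(F)c1`, is the only member of this set with a definite number in an ADME assay on HaCaT cells (Homo sapiens) for inhibition (a lower number here means a stronger inhibitor, a higher number a weaker inhibitor), where compound 1 gives 148000 nM. Compound 2, `COc1cc(-c2cc(C(=O)O)c3ccccc3n2)ccc1OCC(=O)NCc1ccccc1`, returned only a limit of the assay in this assay, > 300000 nM. Among the measured compounds shown here, the one measured step, an at least 2.0-fold higher number from compound 1 to compound 2 (0.30 log units; that floor lies within the scatter), is therefore itself a floor rather than a fixed size, and one of the two values sits at the limit of > 300000 nM in this assay, at which 1 of the 2 values shown sits.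

Compound 3, `COc1cc(-c2cc(C(=O)O)c3ccccc3n2)ccc1OCC(=O)NCc1cccs1`, differs from compound 1 by (thiophen-2-yl)methyl in place of 3-fluorophenyl on an amide-type nitrogen. For the measured compounds named here, this is the same kind of exchange as the step to compound 2, an aryl on the amide-type nitrogen giving way to a one-carbon-linked aromatic, so that step is the only guide here. Compound 3 is expected to move in the same direction, with a step of about a 2.0-fold higher number from compound 1 to compound 3 (0.31 log units; beyond the scatter), and a fair chance that this assay again reports only a limit. The estimate for compound 3 in this assay is 300000 nM, with a range from 120000 nM to 800000 nM.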

Compound 3, half-maximal inhibitory concentration: > 300000 nM
Compound 3: no number, only a limit; the forecaster's own chance of this, stated with the estimate: 50%; the middle value sits exactly at the limit.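

In this assay compound 3 gives > 300000 nM, which is a limit of the assay and not a number. Replacing 3-fluorophenyl with (thiophen-2-yl)methyl on the amide-type nitrogen gives an at least 2.0-fold higher number from compound 1 to compound 3 (0.30 log units; that floor lies within the scatter), so this second one-carbon-linked aromatic also yields a floor and no fixed size. The steps between the two limits cannot be read, so phenyl and thiophen-2-yl on the saturated chain carbon are not separated, and the series can be read from one side only: the limit of > 300000 nM in this assay, at which 2 of the 3 values shown sit.

Open, on these data alone, is whether the one-carbon link or the fluorine matters more, which 3-fluorobenzyl on the amide-type nitrogen would help to separate. Among these compounds, also open is how an amine or a carboxylic acid on this side chain would compare with compound 1 at 148000 nM, the only definite number.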